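From acetamido to methoxy: a step against a limit

This account rests on a few compounds, and the source may have more. Where it says the series, first, only, none or still open, it means among the compounds named here.

Working notes on the series in an ADME assay on MCF-10A cells (Homo sapiens) for cytotoxicity, read by WST assay, with a stated time of 48 h; a higher number here means a weaker inhibitor, a lower number a stronger inhibitor. Compound 1 `O=C(NNC(=S)Nc1ccc([N+](=O)[O-])cc1)c1ccncc1` reads > 300000 nM, which is a limit of the assay and not a number. Compound 2 `CC(=O)Nc1ccc(NC(=S)NNC(=O)c2ccncc2)cc1` reads > 300000 nM, which is likewise a limit and not a number. Among the compounds with values here, compound 2 therefore has no numerical position, and the one other reading offers no number to compare it with. The whole measured set rests on (the limit of > 300000 nM in this assay, at which 2 of the 2 values shown sit).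

Within the data shown here, the only measured step is a step that the two limits leave unreadable from compound 1 to compound 2, with acetamido in place of nitro on an aromatic carbon. It provides no size to carry forward.

The change now followed is methoxy in place of acetamido on an aromatic carbon. Methoxy takes the place of acetamido on an aromatic carbon, para to a large group, and gives compound 3 `COc1ccc(NC(=S)NNC(=O)c2ccncc2)cc1`.

The expectation rests on compound 2, whose > 300000 nM is a limit, so nothing measured points to a step beyond the scatter in this assay. The expected result is a number no higher from compound 2 to compound 3 (the limit leaves the size open), with no direction supported by the data. Compound 3 is estimated at 300000 nM, with an expected range of 150000 nM to 600000 nM.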

Compound 3, half-maximal inhibitory concentration: 47500 nM
For compound 3 the middle estimate is 6.3-fold (0.80 log units) above the measured one; measured number outside the range, below it.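

In this assay, within the data shown here, compound 3 gives the series its only reading that is a number and not a limit, which shows that the group on this aromatic carbon, para to a large group, can move the read-out: methoxy in place of acetamido gives an at least 6.3-fold lower number from compound 2 to compound 3 (0.80 log units; beyond the scatter). Methoxy in place of nitro on the same carbon gives an at least 6.3-fold lower number from compound 1 to compound 3 (0.80 log units; beyond the scatter), so both steps to methoxy run in the same direction, something the unreadable step between the two earlier compounds could not show. Both sizes are lower bounds and not measured differences, and the true steps may be larger: the limit of > 300000 nM in this assay, at which 2 of the 3 values shown sit.

Open, on these data alone, is whether the lower number is particular to methoxy or would also come with a hydroxyl, an amine or a longer alkoxy chain on this carbon. Among these compounds, also open is where a chlorine or a carboxylic acid would fall, as methoxy alone gives a number here and the shared core has so far been read with only three groups at this place.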